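The compounds below may be only part of what the source reports. "The series", "measured", "known", "first", "only" and "open" are said of these compounds alone.

In a functional assay on PC-3 cells (Homo sapiens) for cytotoxicity, read by MTT assay, with a stated time of 72 h (on this read-out higher numbers stand for weaker inhibition and lower numbers for stronger inhibition), the three measured compounds stand as follows:
compound 1 `Cc1ccc(S(=O)(=O)c2nc3ccccc3nc2N2CCc3ccccc3C2)cc1` gives 22400 nM;
compound 2 `O=S(=O)(c1ccc(Br)cc1)c1nc2ccccc2nc1N1CCc2ccccc2C1` gives a limit of the assay, > 50000 nM;
compound 3 `O=S(=O)(c1ccc(F)cc1)c1nc2ccccc2nc1N1CCc2ccccc2C1` gives 9230 nM.

Compound 3 thus holds the lowest of the two actual numbers in this assay, with compound 1 nearest: a 2.4-fold lower number from compound 1 to compound 3 (0.39 log units; beyond the scatter). Compound 2 contributes only a limit (the limit of > 50000 nM in this assay, at which 1 of the 3 values shown sits).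

Compound 4 `O=S(=O)(c1ccc(F)cc1)c1nc2ccccc2nc1N1CCCC(O)C1` differs from compound 3 by 3-hydroxypiperidin-1-yl in place of 1,2,3,4-tetrahydroisoquinolin-2-yl on an aromatic carbon. Every measured step — an at least 2.2-fold higher number from compound 1 to compound 2 (0.34 log units; beyond the scatter), a 2.4-fold lower number from compound 1 to compound 3 (0.39 log units; beyond the scatter), an at least 5.4-fold lower number from compound 2 to compound 3 (0.73 log units; beyond the scatter) — alters the substituent on the sulfonyl-bearing aromatic ring and leaves the amine untouched, so none bears directly on this change. The expectation for compound 4 in this assay therefore rests on little, with a modest drift to a higher number judged most likely: a 2.2-fold higher number from compound 3 to compound 4 (0.34 log units; beyond the scatter). Compound 4 is estimated at 20000 nM, within 6000 nM to 50000 nM.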

Compound 4, half-maximal inhibitory concentration: 2130 nM
Compound 4: the middle estimate sits 9.4-fold (0.97 log units) above what was measured, outside the stated range (below it).
By their numbers in this assay, from the lowest: compound 4; then compound 3; then compound 1. At a limit, above all of these: compound 2.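

In this assay, within the data shown here, the earlier steps all changed the substituent on the sulfonyl-bearing aromatic ring, whereas this one shows that the amine place, next to the ring nitrogen, also moves the number: a 4.3-fold lower number from compound 3 to compound 4 (0.64 log units; beyond the scatter). So 1,2,3,4-tetrahydroisoquinolin-2-yl is not required there for a low number, and 3-hydroxypiperidin-1-yl serves better in this pair. Nothing shown explains this step. From the compounds shown here alone, it remains open whether the hydroxy group or the piperidine ring accounts for the drop, which a plain piperidine or a 3-aminopiperidin-1-yl group would help to separate. Going by these compounds, whether the same exchange holds with methyl or bromo in place of fluoro is also open.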